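Aryl amide in place of benzyl-type amide on the shared core

A few compounds are considered here, and "the series" means these few. Any claim that something is new, unique, unknown or untested is made for them only; others in the source may bear on it.

Compound 1 `O=C(/C=C/c1coc2cc(O)ccc2c1=O)NCc1ccccc1` carries a benzyl amide on the shared core. In a functional assay on A549 cells (Homo sapiens) for inhibition, read by MTT assay, with a stated time of 48 h (on this read-out lower numbers stand for stronger inhibition and higher numbers for weaker inhibition), compound 1 returns only the limit > 100000 nM, not a number. Compound 3 `O=C(/C=C/c1coc2cc(O)ccc2c1=O)Nc1ccccc1` differs from it by phenyl in place of benzyl on the amide-type nitrogen, and in this assay compound 3 gives 24400 nM. Going by the values given here, the step of an at least 4.0-fold lower number from compound 1 to compound 3 (0.61 log units; beyond the scatter) is the only measured step.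

Compound 2 `COc1ccc2c(=O)c(/C=C/C(=O)NCc3ccccc3F)coc2c1` carries a 2-fluorobenzyl amide on the methoxy-bearing core. In this assay, among the compounds with values here, compound 2 also sits at the limit > 100000 nM and not at a number, so it stands at the limit of > 100000 nM in this assay, at which 2 of the 3 values shown sit, together with compound 1; no step from compound 2 to compound 3 is established, only that compound 3 is the one of the three with a number.

Compound 4 `COc1ccc2c(=O)c(/C=C/C(=O)Nc3ccc(C)cc3)coc2c1` is the unmeasured one. Its change from compound 2 is 4-methylphenyl in place of 2-fluorobenzyl on an amide-type nitrogen. This is the same kind of move as from compound 1 to compound 3, a benzyl-type group replaced by an aryl group on the amide-type nitrogen, and the step there lowered the number. Within the data shown here, the pattern rests on one pair only, and compound 4 adds a methyl group and a methoxy core for which no separate step exists.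

On this basis compound 4 is expected to move below the limit, with an estimated step of an at least 3.3-fold lower number from compound 2 to compound 4 (0.52 log units; beyond the scatter). Compound 4 is estimated at 30000 nM in this assay, within 8000 nM to 100000 nM, with a real chance that only a limit is again reported.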

Compound 4, half-maximal inhibitory concentration: 17500 nM
The estimate for compound 4 lay 1.7-fold (0.23 log units) above the measured number; low and high end bracket the measured number.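

The replacement of a benzyl-type group by an aryl group on the amide-type nitrogen now holds on a second pair: in this assay the new pair shows an at least 5.7-fold lower number from compound 2 to compound 4 (0.75 log units; beyond the scatter) and the earlier pair shows an at least 4.0-fold lower number from compound 1 to compound 3 (0.61 log units; beyond the scatter), in the same direction, and no pair shown goes against it. The change is therefore no longer tied to the core of compound 1, as it also holds on the methoxy-bearing core, and the aryl group may carry a 4-methyl substituent with a number still returned. The new step gives only a minimum size, as the value of compound 2 is a limit and not a number: the limit of > 100000 nM in this assay, at which 2 of the 4 values shown sit.

Compound 3 and compound 4 differ in more than one place, so the separate contributions of the methyl group and the methoxy-bearing core cannot be read, and the two steps, both resting on limits, cannot be ranked by size. Also open, going by these compounds, is how the number would respond to 4-aminophenyl, 4-carboxyphenyl or a longer chain such as phenethyl on the amide-type nitrogen.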